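One Sulfonyl Change Repeated on a Second Core

This account rests on a few compounds, and the source may have more. Where it says the series, first, only, none or still open, it means among the compounds named here.

The series starts from compound 1 `CN1CCN(c2cn(S(=O)(=O)c3ccccc3Br)c3ccc(Br)cc23)CC1`, which in an assay on HeLa cells for displacement of a labelled ligand from 5-hydroxytryptamine receptor 6 (Homo sapiens) (on this read-out higher numbers stand for weaker inhibition and lower numbers for stronger inhibition), gives 10.2 nM. Compound 2 `CN1CCN(c2cn(S(=O)(=O)c3ccc(F)cc3)c3ccc(Br)cc23)CC1` keeps the core of compound 1 and carries the change (4-fluorophenyl in place of 2-bromophenyl on a sulfonyl sulfur). In this assay compound 2 gives 9.2 nM, so the step of a 1.1-fold lower number from compound 1 to compound 2 (0.04 log units; within the scatter) hardly moves the number at all.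

Compound 3 `CCN1CCN(c2cn(S(=O)(=O)c3ccccc3Br)c3ccc(Cl)cc23)CC1` stands on a second core; the difference between the two cores is not broken down here. In this assay compound 3 gives 20.3 nM, the highest of the three numbers, with compound 1 nearest within the scatter and compound 2 furthest, beyond it.

Compound 4 `CCN1CCN(c2cn(S(=O)(=O)c3ccc(F)cc3)c3ccc(Cl)cc23)CC1` has not yet been measured. It is related to compound 3 by the change (4-fluorophenyl in place of 2-bromophenyl on a sulfonyl sulfur), the same change that separates compound 1 from compound 2, since the place around the sulfonyl sulfur is described in the same words in both cases. Among the measured compounds shown here, because the only measured instance of this change, a 1.1-fold lower number from compound 1 to compound 2 (0.04 log units; within the scatter), is within the scatter, compound 4 is expected to stay close to compound 3 in this assay. The step this estimate implies is a 1.1-fold lower number from compound 3 to compound 4 (0.04 log units; within the scatter). Compound 4 is therefore expected to give 18.5 nM, with a likely range from 9 nM to 38 nM. This rests on a single earlier occurrence of the change, so the range is kept wide.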

Compound 4, inhibition constant: 10.7 nM
Compound 4: the middle estimate sits 1.7-fold (0.24 log units) above what was measured; the range from low to high includes it.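

On the core of compound 3, putting 4-fluorophenyl in place of 2-bromophenyl on the sulfonyl sulfur gives a 1.9-fold lower number from compound 3 to compound 4 (0.28 log units; within the scatter) in this assay, and this step, like the one on the core of compound 1, stays inside the usual scatter. Set side by side, the two steps cannot be told apart, and on these two cores the change reads the same: the same change on two cores in this assay, a 1.1-fold lower number (0.04 log units; within the scatter) from compound 1 to compound 2 and a 1.9-fold lower number (0.28 log units; within the scatter) from compound 3 to compound 4, 1.7-fold (0.23 log units) apart, within the scatter of two such steps. Among the compounds shown here, this shows only that the change behaves alike on this one pair of cores; neither step stands beyond the scatter, so the result does not show that the change itself shifts the number in this assay, and two cores are too few to show that it would carry over to a third.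

The compounds shown leave open how other groups on the sulfonyl sulfur would read in this assay, such as a plain phenyl, a methoxyphenyl or an open alkyl chain, any of which might give a step large enough to compare across cores. They also leave open how much of the difference between the two cores rests on each of its parts, and whether a longer chain in the core would alter the picture.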